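This account rests on a few compounds, and the source may have more. Where it says the series, first, only, none or still open, it means among the compounds named here.

Working notes on the series. The shared core is varied only at the carbonyl carbon next to the amide-type nitrogen; the measured members are compound 1 `CCCC(=O)Nc1ccc(N2CCN(c3ccc(OC[C@@H]4CO[C@@](Cn5cncn5)(c5ccc(Cl)cc5Cl)O4)cc3)CC2)cc1`, compound 2 `O=C(CCc1ccccc1)Nc1ccc(N2CCN(c3ccc(OC[C@@H]4CO[C@@](Cn5cncn5)(c5ccc(Cl)cc5Cl)O4)cc3)CC2)cc1` and compound 3 `O=C(Nc1ccc(N2CCN(c3ccc(OC[C@@H]4CO[C@@](Cn5cncn5)(c5ccc(Cl)cc5Cl)O4)cc3)CC2)cc1)C(/C=C/Cl)C/C=C/C(F)(F)F`. In a functional assay on A549 cells (Homo sapiens) for inhibition, read by MTT assay, with a stated time of 48 h (on this read-out higher numbers stand for weaker inhibition and lower numbers for stronger inhibition), compound 1 gives 2990 nM, compound 2 gives 2060 nM and compound 3 gives 3830 nM. Compound 3 stands apart from neither of the others: a 1.3-fold higher number from compound 1 to compound 3 (0.11 log units; within the scatter) and a 1.9-fold higher number from compound 2 to compound 3 (0.27 log units; within the scatter), while a 1.5-fold lower number from compound 1 to compound 2 (0.16 log units; within the scatter). Compound 4 `O=C(Nc1ccc(N2CCN(c3ccc(OC[C@@H]4CO[C@@](Cn5cncn5)(c5ccc(Cl)cc5Cl)O4)cc3)CC2)cc1)c1cccc(F)c1` continues the exchange at that carbon: 3-fluorophenyl in place of 1-(2-chloroethenyl)-5,5,5-trifluoropent-3-en-1-yl on a carbonyl carbon. Since the two prior exchanges there, a 1.3-fold higher number from compound 1 to compound 3 (0.11 log units; within the scatter) and a 1.9-fold higher number from compound 2 to compound 3 (0.27 log units; within the scatter), moved nothing beyond the scatter, the step of a 1.5-fold lower number from compound 3 to compound 4 (0.17 log units; within the scatter) is expected to remain within it. Compound 4 is therefore estimated at 2600 nM in this assay, with a range of 1000 nM to 7000 nM.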

Compound 4, half-maximal inhibitory concentration: 6640 nM
Beside the measured number, compound 4's estimate is 2.6-fold (0.41 log units) below it; low and high end bracket the measured number.
By their numbers in this assay, from the lowest: compounds 2, 1, 3 and 4 (each within the scatter of the next, the first and the last beyond it).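

Among these compounds, at the carbonyl carbon, 3-fluorophenyl gives the only steps that pass the scatter in this assay: a 3.2-fold higher number from compound 2 to compound 4 (0.51 log units; beyond the scatter) and a 2.2-fold higher number from compound 1 to compound 4 (0.35 log units; beyond the scatter) are both modest and both point to weaker inhibition. Against 1-(2-chloroethenyl)-5,5,5-trifluoropent-3-en-1-yl the same group does not pass it, with a 1.7-fold higher number from compound 3 to compound 4 (0.24 log units; within the scatter) as the step. Open, on these data alone, is whether plain phenyl on that carbonyl carbon would read like compound 4 and how a longer chain ending in an amine would read. Nothing available accounts for these steps.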